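The source may hold more compounds than are shown below. What is called first, only, known or untested is meant among the compounds shown, and "the series" means these compounds.

Of the compounds shown here, three from one series have been measured in an assay on HEK293 cells for inhibition of Voltage-dependent T-type calcium channel subunit alpha-1G (Homo sapiens), read by patch clamp, tested at 10 uM; on this read-out higher numbers stand for more inhibition at the one concentration tested (going by the name of the read-out) and lower numbers for less inhibition. Compound 1 `COc1ccccc1N1CCN(C[C@@H](O)COc2ccc(Cl)cc2)CC1` gives 47.4% in this assay. Compound 2 `O[C@H](COc1ccc(Cl)cc1)CN1CCN(c2ccccc2F)CC1` gives 35.9% in this assay. Compound 3 `O[C@@H](COc1ccc(Cl)cc1)CN1CCN(c2ccc(F)cc2)CC1` gives 39.7% in this assay, which places it second of the three numbers: its nearest neighbour is compound 2, and its furthest is compound 1, with both gaps within the scatter of repeated measurements, so the three compounds cannot be told apart on these figures.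

The next compound, compound 4 `O[C@@H](COc1ccc(Cl)cc1)CN1CCN(c2ccccc2F)CC1`, has not yet been measured. It differs from compound 3 in one place (2-fluorophenyl in place of 4-fluorophenyl on an amine nitrogen in a ring). Within the data shown here, no measured step covers this exact change. Among the measured compounds shown here, the one step that has been measured in this assay, a number 7.7 percentage points lower from compound 1 to compound 3 (within the scatter), swapped the whole group on the same ring nitrogen and stayed within the scatter. Compound 2, which also carries a 2-fluorophenyl on that nitrogen, gives a number close to compound 3. Taken together, no step beyond the scatter is expected for a number 1.7 percentage points lower from compound 3 to compound 4 (within the scatter). Compound 4 is therefore estimated at 38% in this assay, with a plausible range from 26% to 50%.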

Compound 4, a percentage reported as inhibition, at one concentration (the size of the read-out at that concentration, not a potency): 46.9%
Compound 4: the middle estimate sits 8.9 percentage points below what was measured, and the stated range covers the measured number.
By their numbers in this assay, from the lowest: compounds 2, 3, 4 and 1 (each within the scatter of the next, the first and the last beyond it).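

With the fluorine moved from 4-fluorophenyl to 2-fluorophenyl on the ring nitrogen, this assay shows a number 7.2 percentage points higher from compound 3 to compound 4 (within the scatter) and so cannot separate the two placements. Fluoro in place of methoxy on the aromatic carbon gives a number 0.5 percentage points lower from compound 1 to compound 4 (within the scatter) and likewise leaves the two groups indistinguishable on this read-out. The new information lies in the stereocentre at the saturated chain carbon, where there is a number 11 percentage points higher from compound 2 to compound 4 (beyond the scatter) as the first single-place step shown that clears the scatter, and this modest gap can be traced to the stereocentre alone because of what separates the pair: the fact that compounds 2 and 4 differ only in the configuration as drawn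

From the compounds shown here alone, compounds 1 and 3 appear here with only one configuration each, so whether the stereocentre matters with 2-methoxyphenyl or 4-fluorophenyl on the ring nitrogen, or only with 2-fluorophenyl, remains open. How a plain phenyl or a 2-chlorophenyl on that nitrogen would read is also open, and a single tested concentration gives no potency for any of these compounds.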